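Cyanomethyl for oxetan-3-yl on the ring amine

This account rests on a few compounds, and the source may have more. Where it says the series, first, only, none or still open, it means among the compounds named here.

Values measured in an in vitro ADME assay on microsomes from liver (Mus musculus) for pharmacokinetics, read by LC-MS, with a stated time of 10 min, tested at 1 uM; on this read-out higher numbers stand for fast clearance and lower numbers for slow clearance:
- Compound 1 `CN1C[C@H](C(=O)Nc2ccc(C#N)cc2)[C@@H](c2ccc(/C=C/C(=O)Nc3ccccc3N)cc2)C1` gives 35 mL/min/kg
- Compound 2 `CN1C[C@H](C(=O)Nc2ccc(Cl)c(Cl)c2)[C@@H](c2ccc(/C=C/C(=O)Nc3ccccc3N)cc2)C1` gives 36 mL/min/kg
- Compound 3 `Nc1ccccc1NC(=O)/C=C/c1ccc([C@H]2CN(C3COC3)C[C@@H]2C(=O)Nc2ccc(Cl)cc2)cc1` gives 42 mL/min/kg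

Compound 3 at 42 mL/min/kg lies within the scatter of both compound 1 and compound 2, so the three values cannot be ranked. Compound 4 `N#CCN1C[C@H](C(=O)Nc2ccc(Cl)cc2)[C@@H](c2ccc(/C=C/C(=O)Nc3ccccc3N)cc2)C1` carries cyanomethyl in place of oxetan-3-yl on an amine nitrogen in a ring and is otherwise the same as compound 3. Among the compounds with values here, the only measured step, a 1.0-fold higher number from compound 1 to compound 2 (0.01 log units; within the scatter), concerns 3,4-dichlorophenyl in place of 4-cyanophenyl on an amide-type nitrogen, so it does not test this place. The expectation therefore rests on compound 3 at 42 mL/min/kg and anticipates no shift beyond the scatter in this assay for this change. The estimated step is a 1.1-fold lower number from compound 3 to compound 4 (0.02 log units; within the scatter) and is expected to stay small. Compound 4 is expected at 40 mL/min/kg (range 22 mL/min/kg to 70 mL/min/kg) when measured.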

Compound 4, clearance: 51 mL/min/kg
Beside the measured number, compound 4's estimate is 1.3-fold (0.11 log units) below it, and the stated range covers the measured number.
By their numbers in this assay, from the lowest: compounds 1, 2, 3 and 4 (each within the scatter of the next).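

Within the data shown here, this is the first reading at the amine nitrogen in the ring: with cyanomethyl in place of oxetan-3-yl, this assay shows a 1.2-fold higher number from compound 3 to compound 4 (0.08 log units; within the scatter). At this place, the read-out therefore does not separate a group with a four-membered non-aromatic ring from one with no ring and a triple bond. Nothing available explains the result. The compounds shown leave open whether a longer alkyl chain or a carboxylic acid on this nitrogen would give a step beyond the scatter. They also leave open whether the same swap would read alike with another group on the amide nitrogen.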